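The source may hold more compounds than are shown below. What is called first, only, known or untested is meant among the compounds shown, and "the series" means these compounds.

For the measured compounds named here, in a functional assay on A549 cells (Homo sapiens) for antiproliferative activity, read by MTT assay, with a stated time of 72 h (on this read-out lower numbers stand for stronger inhibition and higher numbers for weaker inhibition), compound 3 `COc1cc(-n2cnc3ccc(-c4ccccc4)cc32)cc(OC)c1OC` gives 3060 nM, the only exact number so far. Compound 1 `COc1cc(-n2cnc3ccc(-c4ccccc4Cl)cc32)cc(OC)c1OC` reads > 10000 nM, which is a limit of the assay and not a number. Compound 2 `COc1cc(-n2cnc3ccc(-c4ccc(C)cc4F)cc32)cc(OC)c1OC` reads > 10000 nM, again a limit. Compound 4 `COc1cc(-n2cnc3ccc(-c4cccc(N)c4)cc32)cc(OC)c1OC` changes compound 3 in one place: amino in place of hydrogen on an aromatic carbon, turning phenyl into 3-aminophenyl. Two measured steps end at the plain phenyl of compound 3: an at least 3.2-fold lower number from compound 1 to compound 3 (0.51 log units; beyond the scatter) and an at least 3.2-fold lower number from compound 2 to compound 3 (0.51 log units; beyond the scatter). Both are at least modest, but neither involves an amino group, so they are only a loose guide. The expected change is small, a 1.2-fold lower number from compound 3 to compound 4 (0.09 log units; within the scatter), with no firm direction beyond the scatter. For compound 4 the estimated value is 2500 nM, with an expected range of 500 nM to 10000 nM.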

Compound 4, half-maximal inhibitory concentration: 640 nM
The estimate for compound 4 lay 3.9-fold (0.59 log units) above the measured number; the measured number falls inside the stated range.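

Putting an amino group on the plain phenyl ring gives a 4.8-fold lower number from compound 3 to compound 4 (0.68 log units; beyond the scatter), the first sign that a group added to this ring can strengthen inhibition rather than weaken it. Set against the other substituted rings, the 3-aminophenyl gives an at least 15-fold lower number from compound 2 to compound 4 (1.19 log units; beyond the scatter) and an at least 15-fold lower number from compound 1 to compound 4 (1.19 log units; beyond the scatter). Both of these steps start from a limit, not a number: the limit of > 10000 nM in this assay, at which 2 of the 4 values shown sit.

Going by these compounds, it remains open whether a hydroxyl, a methylamino or an acetamide group in the same place would do as well. On these data alone, it is equally open whether the amino group would have this effect elsewhere on the ring.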